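The source may hold more compounds than are shown below. What is called first, only, known or untested is meant among the compounds shown, and "the series" means these compounds.

Compound 2 `COc1cc(-c2nnc(SCc3ccccc3)n2N2C(=O)c3ccccc3C2=O)cc(OC)c1OC` carries a benzylsulfanyl group on the shared core, and its companion compound 1 `C#CCSc1nnc(-c2cc(OC)c(OC)c(OC)c2)n1N1C(=O)c2ccccc2C1=O` differs from it only in having an ethynyl group in place of the phenyl on the saturated chain carbon bound to sulfur. In a functional assay on A549 cells (Homo sapiens) for cytotoxicity, read by MTT assay, with a stated time of 48 h (a lower number here means a stronger inhibitor, a higher number a weaker inhibitor), compound 1 reaches only the limit of the measurement, > 200000 nM. In this assay compound 2 likewise gives only the limit, > 200000 nM. The step that the two limits leave unreadable from compound 1 to compound 2 therefore cannot be read, because both ends sit at the limit of > 200000 nM in this assay, at which 2 of the 2 values shown sit. Compound 3 `COc1cc(-c2nnc(SCC(=O)c3ccccc3)n2N2C(=O)c3ccccc3C2=O)cc(OC)c1OC` is the next variation: benzoyl in place of phenyl on a saturated chain carbon bound to a sulfur. For the measured compounds named here, no measured step speaks to this exchange, and the one neighbouring step offers no readable size in either direction. With both known values resting at the limit, compound 3 is expected to land near that same limit in this assay, and its value is estimated at 200000 nM, within a range from 50000 nM to 500000 nM. The step expected from the benzyl to the benzoylmethyl compound is accordingly a number no higher from compound 2 to compound 3 (the limit leaves the size open), with a substantial chance that only a limit is again reported.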

Compound 3, half-maximal inhibitory concentration: > 200000 nM
Compound 3: no number, only a limit (the forecaster's own chance of this, stated with the estimate: 70%); the middle value sits exactly at the limit.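

In this assay compound 3 gives only a limit, > 200000 nM. For the compounds shown here, no step from compound 3 to compound 1 or compound 2 can therefore be read, because all three compounds share one end point: the limit of > 200000 nM in this assay, at which 3 of the 3 values shown sit. The compounds shown leave open how the ethynyl, phenyl and benzoyl groups on the saturated chain carbon bound to a sulfur rank against one another in this assay.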